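The compounds below may be only part of what the source reports. "The series", "measured", "known", "first", "only" and "open" are said of these compounds alone.

Among the measured compounds shown here, compound 3, `CC(C)C(c1nnc[nH]1)c1ccc(-c2ccc3cccc(F)c3c2)[nH]c1=O`, gives 21 nM in a functional assay on CHO cells for antagonist activity at prostaglandin E2 receptor EP3 subtype (Homo sapiens), read by cAMP accumulation (a higher number here means a weaker inhibitor, a lower number a stronger inhibitor), the lowest of the three numbers known here; compound 2, `CC(C)C(c1ccc(-c2ccc3cccc(F)c3c2)[nH]c1=O)N1CCN/C1=N\C#N`, stands within the scatter of it with 38 nM, while compound 1, `CC(C)C(Nc1nnc[nH]1)c1ccc(-c2ccc3cccc(F)c3c2)[nH]c1=O`, lies furthest away with 185 nM. Compound 4, `CC(C)C(c1cnc(N)s1)c1ccc(-c2ccc3cccc(F)c3c2)[nH]c1=O`, differs from compound 3 only by 2-amino-1,3-thiazol-5-yl in place of 4H-1,2,4-triazol-3-yl on a saturated chain carbon bound to an aromatic carbon and a saturated chain carbon. Every step measured so far touches this same carbon: an 8.8-fold lower number from compound 1 to compound 3 (0.94 log units; beyond the scatter) and a 4.9-fold lower number from compound 1 to compound 2 (0.69 log units; beyond the scatter) were both modest but beyond the scatter, whereas a 1.8-fold lower number from compound 2 to compound 3 (0.26 log units; within the scatter) stayed within it. For the measured compounds named here, the two compounds that carry a ring directly on that carbon, compound 2 and compound 3, thus sit close together, and the only large changes came from removing the amino link of compound 1. Going by the values given here, no measured step swaps one directly attached aromatic ring for another, so the effect of the thiazole is unknown; the nearest precedent, compound 2 with 38 nM, suggests a small move at most. Compound 4 is therefore expected to fall near 45 nM, with a range of 12 nM to 170 nM, a step of a 2.1-fold higher number from compound 3 to compound 4 (0.33 log units; beyond the scatter).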

Compound 4, half-maximal inhibitory concentration: 39 nM
Estimate against measurement, compound 4: 1.2-fold (0.06 log units) above; the measured number falls inside the stated range.
By their numbers in this assay, from the lowest: compounds 3, 2 and 4 (each within the scatter of the next); then compound 1.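

In this assay, one directly attached aromatic ring has now been exchanged for another on the saturated chain carbon, and a 1.9-fold higher number from compound 3 to compound 4 (0.27 log units; within the scatter) stays within the scatter. So does a 1.0-fold higher number from compound 2 to compound 4 (0.01 log units; within the scatter), which means that the three different five-membered rings carried on this carbon cannot be told apart, even with sulfur entering in the 2-amino-1,3-thiazol-5-yl group. Among the compounds shown here, with a 4.7-fold lower number from compound 1 to compound 4 (0.68 log units; beyond the scatter) lying beyond the scatter, compound 1, with its (4H-1,2,4-triazol-3-yl)amino group, remains the only compound set apart, and nothing given here explains why these rings read alike.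

Still open, from the compounds shown here alone, is whether a phenyl ring, a carboxylic acid or a plain amine on this carbon would fall in the same range. Also open, going by these compounds, is what an unsubstituted 1,3-thiazol-5-yl group would give, which would isolate the part played by the amino group on the thiazole.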